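Trifluoromethyl Substitution in a Prostate Cancer Cell Assay

The source may hold more compounds than are shown below. What is called first, only, known or untested is meant among the compounds shown, and "the series" means these compounds.

Compound 1, `CC1=CCCC(C)(C)C1/C=C/C(=O)/C=C/c1ccccc1C(F)(F)F`, 19000 nM
Compound 2, `CC1=CCCC(C)(C)C1/C=C/C(=O)/C=C/c1cccc([N+](=O)[O-])c1`, 2900 nM
Compound 3, `CC1=C(/C=C/C(=O)/C=C/c2ccccc2)C(C)(C)CCC1O`, 15500 nM

These three compounds were tested in a functional assay on PC-3 cells (Homo sapiens) for cytotoxicity, read by MTT assay, with a stated time of 72 h; on this read-out lower numbers stand for stronger inhibition and higher numbers for weaker inhibition. Compound 3 stands second highest of the three numbers; its nearest neighbour is compound 1, whose value lies within the scatter of compound 3, while compound 2 sits furthest away, with a number clearly lower than that of compound 3.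

Compound 4, `CC1=C(/C=C/C(=O)/C=C/c2ccccc2C(F)(F)F)C(C)(C)CCC1O`, keeps the core of compound 3 and differs only by trifluoromethyl in place of hydrogen on an aromatic carbon. For the measured compounds named here, no step of exactly this kind between two measured compounds is available, so the expectation rests on the nearby numbers, in particular compound 1, which also carries trifluoromethyl and gives 19000 nM. For compound 4 a step of a 1.2-fold higher number from compound 3 to compound 4 (0.06 log units; within the scatter) is expected, with no change beyond the scatter. Compound 4 is therefore estimated at 18000 nM, within a range from 8000 nM to 40000 nM.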

Compound 4, half-maximal inhibitory concentration: 3700 nM
The estimate for compound 4 lay 4.9-fold (0.69 log units) above the measured number; measured number outside the range, below it.
By their numbers in this assay, from the lowest: compounds 2 and 4 (each within the scatter of the next); then compounds 3 and 1 (each within the scatter of the next).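

Within this assay trifluoromethyl in place of hydrogen on an aromatic carbon, ortho to a large group, gives a 4.2-fold lower number from compound 3 to compound 4 (0.62 log units; beyond the scatter) and supplies the first comparison between compounds differing in one place. It shows that the number responds to a change at this position on the core of compound 3, which compounds 1 and 2 could not show.

From the compounds shown here alone, whether a chlorine atom, a methoxy group or an amine in the same place would give a similar step stays open. No measured property bears on why the number fell.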